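The source may report more compounds than this note shows. Statements on the series, on what has been measured and on what is new or still open speak of the compounds shown alone.

Measured in a functional assay on A549 cells (Homo sapiens) for cytotoxicity, read by MTT assay, with a stated time of 48 h; on this read-out lower numbers stand for stronger inhibition and higher numbers for weaker inhibition:
- Compound 1 `COc1ccc(/C=C/c2cc(OC)c(OC)c(OC)c2-c2ccc(F)c(F)c2)cc1`: 7500 nM
- Compound 2 `COc1cc(/C=C/c2ccccc2)c(-c2ccccc2)c(OC)c1OC`: 79000 nM
- Compound 3 `C=C(c1ccc(OC)cc1)c1cc(OC)c(OC)c(OC)c1-c1ccc(F)c(F)c1`: 6500 nM

Compound 2, at 79000 nM, has the highest number of the three, and its gaps to compound 1 and compound 3 both lie beyond the scatter. Compound 4 `C=C(c1ccc(Cl)cc1)c1cc(OC)c(OC)c(OC)c1-c1ccccc1` differs from compound 2 in one place: 1-(4-chlorophenyl)ethenyl in place of 2-phenylethenyl on an aromatic carbon. In words, 1-(4-chlorophenyl)ethenyl stands in place of 2-phenylethenyl on an aromatic carbon, ortho to a phenyl group.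

Going by the values given here, one measured step bears on the shift of the ethenyl attachment: a 1.2-fold lower number from compound 1 to compound 3 (0.06 log units; within the scatter). It suggests that this part of the change alone moves little. Among the compounds with values here, no measured pair isolates the chlorine. Compound 1 and compound 3 have lower numbers than compound 2, but they differ from it in more than one place, so their gap cannot be assigned to this change. In this assay, within the data shown here, only a modest fall is therefore expected, with no large step. The expected step is a 2.0-fold lower number from compound 2 to compound 4 (0.30 log units; within the scatter). Compound 4 is estimated at 40000 nM, with an expected range from 15000 nM to 100000 nM.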

Compound 4, half-maximal inhibitory concentration: 40000 nM
The estimate for compound 4 equals the measured number at the digits printed; the measured number falls inside the stated range.
By their numbers in this assay, from the lowest: compounds 3 and 1 (each within the scatter of the next); then compounds 4 and 2 (each within the scatter of the next).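

In this assay, the change at this position, ortho to a phenyl group, gives a 2.0-fold lower number from compound 2 to compound 4 (0.30 log units; within the scatter), so a swap that both moves the ethenyl attachment and adds a chlorine still stays within the scatter. The earlier step, a 1.2-fold lower number from compound 1 to compound 3 (0.06 log units; within the scatter), covered only the shift of attachment with a 4-methoxyphenyl group in place, and the new step shows the same small size for a different aryl group on a compound bearing an unsubstituted phenyl group. No measurement shown here accounts for this result.

The compounds shown do not separate the part played by the chlorine from that of the shifted attachment. As far as these compounds go, it also remains open whether an amine or a carboxylic acid in place of the chlorine would move the number beyond the scatter.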